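The source may report more compounds than this note shows. Statements on the series, on what has been measured and on what is new or still open speak of the compounds shown alone.

Measured so far in a physicochemical assay for lipophilicity; a higher number here means a more lipophilic compound, a lower number a more polar compound:
compound 1 `NS(=O)(=O)Oc1ccc2c(c1)CN(C(=O)c1ccc(N(Cc3ccccc3)Cc3ccco3)cc1)CC2` gives 1.93
compound 2 `CCN(Cc1ccc(Br)cc1)c1ccc(C(=O)N2CCc3ccc(OS(N)(=O)=O)cc3C2)cc1` gives 1.93

Compound 1 stands level with compound 2 at the digits shown; the two values lie within the scatter of repeated measurements in this assay, so nothing separates them. Among the measured compounds shown here, no pair of measured compounds differs in a single place, so no step of known size exists.

Compound 3 `CN(C)CCCN(Cc1ccccc1)c1ccc(C(=O)N2CCc3ccc(OS(N)(=O)=O)cc3C2)cc1` has not yet been measured. It is obtained from compound 1 by the change (2-(dimethylamino)ethyl in place of furan-2-yl on a saturated chain carbon bound to a nitrogen on an aromatic ring). The change keeps the count of heavy atoms, of hydrogen-bond donors and of hydrogen-bond acceptors the same, and trades a five-membered aromatic ring with one hetero atom for a chain with no ring.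

For the measured compounds named here, with no measured step to lean on, the expectation rests on the change alone. Compound 3 in this assay is expected near 0.9, with a range from 0.2 to 1.6. A drop beyond the scatter is expected, a number 1.03 log units lower from compound 1 to compound 3 (beyond the scatter), though its size is uncertain.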

Compound 3, partition coefficient: 1.93
For compound 3 the middle estimate is 1.03 log units below the measured one; the measured number lies above the stated range.
By their numbers in this assay, from the lowest: compounds 1, 2 and 3 (each within the scatter of the next).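

In this assay, among the compounds shown here, 2-(dimethylamino)ethyl in place of furan-2-yl on a saturated chain carbon bound to a nitrogen on an aromatic ring gives no change at the digits printed from compound 1 to compound 3 (within the scatter), which provides the first measured step at this position. Trading a five-membered aromatic ring with one hetero atom for a chain with no ring, at equal counts of heavy atoms, hydrogen-bond donors and hydrogen-bond acceptors, therefore leaves this read-out unseparated for this pair, though one pair on the core of compound 1 establishes no rule for the position. No measurement in hand bears on why the two compounds read alike.

For the compounds shown here, no single-place step links compound 2 to either of the other compounds, so it adds nothing about this position. On these data alone, it remains open whether a carboxylic acid, a primary amine or a longer dimethylamino chain at the same place would also stay within the scatter of compound 1, and whether the same exchange would read alike on a different group at the neighbouring substituent of the shared core.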